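Amino for chloro on the shared purine-type core of compound 1

This account rests on a few compounds, and the source may have more. Where it says the series, first, only, none or still open, it means among the compounds named here.

Three close analogues have been run in a functional assay on SF-295 cells (Homo sapiens) for cytotoxicity, read by sulforhodamine B assay, with a stated time of 48 h; on this read-out higher numbers stand for lower toxicity in this test and lower numbers for higher toxicity in this test. Compound 1 `ClCc1cccc(Cn2cnc3c(Cl)nc(Cl)nc32)c1` gives 45700 nM. Compound 3 `ClCc1ccccc1Cn1cnc2nc(Cl)nc(Cl)c21` gives 61700 nM and compound 2 `Nc1nc(Cl)c2ncn(Cc3ccc(CCl)cc3)c2n1` gives 72400 nM; the spread among these three numbers stays inside the usual scatter of this assay, so compound 1 sits with the others rather than apart from them.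

Compound 4 `Nc1nc(Cl)c2ncn(Cc3cccc(CCl)c3)c2n1` has not been measured. It differs from compound 1 as follows: amino in place of chloro on an aromatic carbon. For the measured compounds named here, no pair differing in one place has been measured, so no step can be borrowed. Compound 2, which already carries the amino group, gives 72400 nM, close to the others, so a step in this assay of no more than the scatter is expected, and for compound 4 a value of 60000 nM (range 25000 nM to 150000 nM) is estimated, meaning a step of a 1.3-fold higher number from compound 1 to compound 4 (0.12 log units; within the scatter).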

Compound 4, concentration lethal to 50% of the cells: 39800 nM
Compound 4: the middle estimate sits 1.5-fold (0.18 log units) above what was measured, and the stated range covers the measured number.
By their numbers in this assay, from the lowest: compounds 4, 1, 3 and 2 (each within the scatter of the next).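

In this assay, for the compounds shown here, a 1.1-fold lower number from compound 1 to compound 4 (0.06 log units; within the scatter) is the first reading of a single change: amino in place of chloro on the aromatic carbon between two ring nitrogen atoms. At this position, then, the added hydrogen-bond donor comes with no step beyond the scatter in this test. Nothing measured here offers an explanation for this result.

Going by these compounds alone, this one pair is the only reading of the position, so it remains open whether methoxy, dimethylamino or morpholine there would also stay within the scatter.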